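Benzyloxy in place of methoxy on the shared core

A few compounds are considered here, and "the series" means these few. Any claim that something is new, unique, unknown or untested is made for them only; others in the source may bear on it.

Compound 2 `COc1ccc(/C=C(/SCc2ccc(Cl)cc2)C(=O)c2ccc(Cl)cc2)cc1` gives 10000 nM in a functional assay on DU-145 cells (Homo sapiens) for inhibition, read by trypan blue exclusion, with a stated time of 96 h; a higher number here means a weaker inhibitor of growth, a lower number a stronger inhibitor of growth. Compound 1 `COc1ccc(/C=C(/SCc2ccc(Cl)cc2)C(=O)c2ccc(Br)cc2)cc1` carries bromo on an aromatic carbon where compound 2 carries chloro; in this assay compound 1 gives 10000 nM, and the step of no change at the digits printed from compound 1 to compound 2 (within the scatter). Compound 3 `COc1ccc(/C=C(/Sc2ccc(Br)cc2)C(=O)c2ccc(Cl)cc2)cc1` gives 50000 nM; the step of a 5.0-fold higher number from compound 2 to compound 3 (0.70 log units; beyond the scatter). Compound 2 thus stands level with compound 1 at the lowest of the three numbers, with compound 3 the furthest from it.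

Compound 4 `O=C(/C(=C\c1ccc(OCc2ccccc2)cc1)SCc1ccc(Cl)cc1)c1ccc(Cl)cc1` has not yet been measured. It differs from compound 2 by phenyl in place of hydrogen on a saturated chain carbon bound to an oxygen on an aromatic ring. Within the data shown here, neither measured step touches this part of the shared core: the halogen exchange and the change on a sulfur sit elsewhere, so the series offers no step of the same kind to lean on. With nothing pointing either way, the step from compound 2 to compound 4 is expected to stay within the scatter, no change at the digits printed from compound 2 to compound 4 (within the scatter). Compound 4 is therefore estimated at 10000 nM in this assay, between 3000 nM and 35000 nM.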

Compound 4, concentration for 50% growth inhibition: 1000 nM
The estimate for compound 4 lay 10-fold (1.00 log units) above the measured number; the measured number lies below the stated range.
By their numbers in this assay, from the lowest: compound 4; then compounds 1 and 2 (each within the scatter of the next); then compound 3.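

In this assay, among these compounds, the change from methoxy to benzyloxy gives a 10-fold lower number from compound 2 to compound 4 (1.00 log units; beyond the scatter), the only step that lowers the number. The saturated chain carbon bound to an oxygen on an aromatic ring is therefore a place where the read-out responds to substitution, whereas the exchange of bromo for chloro on an aromatic carbon left the number unchanged at the digits printed. The data shown give no reason for this response.

A single step cannot show whether the phenyl ring itself is needed or whether an ethoxy, a longer alkoxy chain or a cyclohexylmethoxy group would serve equally. Also open, as far as these compounds go, is whether benzyloxy would lower the number in the same way on compound 3, with its 4-bromophenyl on the sulfur.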